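The source may report more compounds than this note shows. Statements on the series, on what has been measured and on what is new or still open speak of the compounds shown alone.

Three compounds of this series, which share one core, have already been measured in a physicochemical assay for pharmacokinetics, read by LC-MS, in phosphate buffer, at pH 7.4, in the presence of a further agent that is not named here; on this read-out lower numbers stand for a shorter-lived compound and higher numbers for a longer-lived compound. Compound 1 `C=CC(=O)N1CC(NC(=O)Cn2c(C)c(C(=O)N3CCc4c(cccc4OC)C3)c3cc(Br)cc(C)c32)C1` gives 1.67 h in this assay. Compound 2 `C=CC(=O)N1CC(NC(=O)COc2ccc(Br)cc2C(=O)N2CC=C(c3ccccc3)C2)C1` gives 1.67 h. Compound 3 `C=CC(=O)N1CC(NC(=O)Cn2cc(C(=O)N3CCc4c(Cl)cccc4C3)c3cc(Br)ccc32)C1` gives 1.67 h, which is level with compounds 1 and 2 at the digits reported: against its nearest neighbour, compound 1, there is no change at those digits, and against the furthest, compound 2, there is none either. All three therefore sit within the usual scatter of each other, and none of them can be called the longer- or shorter-lived one.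

Compound 4 `C=CC(=O)N1CC(NC(=O)Cn2cc(C(=O)N3CCc4c(cccc4OC)C3)c3cc(Br)ccc32)C1` has not yet been measured. It differs from compound 3 in one place: methoxy in place of chloro on an aromatic carbon. For the measured compounds named here, no pair of measured compounds differs in exactly this way, so no measured step shows what this swap does in this assay. What the data offer is that compound 1, which carries a methoxy group, and compound 3, which carries a chloro group, give values that are level with each other. For compound 4 the step is expected to be none beyond the scatter, namely no change at the digits printed from compound 3 to compound 4 (within the scatter). Compound 4 is accordingly estimated at 1.67 h, within a range from 0.9 h to 3.2 h.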

Compound 4, half-life: 1.67 h
Beside the measured number, compound 4's estimate shows no gap at the digits printed; measured number inside the range.
By their numbers in this assay, from the lowest: compounds 1, 2, 3 and 4 (each within the scatter of the next).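

For the compounds shown here, this is the first direct reading of this swap in this assay: putting methoxy in place of chloro on an aromatic carbon, ortho to a fused ring and meta to a fused ring, gives no change at the digits printed from compound 3 to compound 4 (within the scatter) and nothing larger. Compounds 1 and 3 also carry these two groups but differ in other places as well, whereas compounds 3 and 4 differ only here, so this pair isolates the change at this one position. Here a chlorine gives way to a carbon and an oxygen, and a hydrogen-bond acceptor enters, yet the half-life stays level; no measurement at hand speaks to why it does.

Every compound shown reads the same in this assay, so it remains open whether this read-out responds to any change at this position, and this single step says nothing about other places on the shared core. An amine, a carboxylic acid or a longer chain on this aromatic carbon would show whether the level value also holds for groups far less like chloro and methoxy.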